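Aryl swap on the amide-type nitrogen of compound 2

A few compounds are considered here, and "the series" means these few. Any claim that something is new, unique, unknown or untested is made for them only; others in the source may bear on it.

- compound 1 `COc1ccc(NC(=O)NCCNS(=O)(=O)c2ccc(-c3ccccc3OCc3ccccc3)s2)cc1`: > 50000 nM
- compound 2 `Nc1ccc(Oc2ccccc2-c2ccc(S(=O)(=O)NCCNC(=O)Nc3ccc(Cl)cc3)s2)cc1`: > 20000 nM
- compound 3 `O=C(NCCNS(=O)(=O)c1ccc(-c2ccccc2Oc2ccc([N+](=O)[O-])c([N+](=O)[O-])c2)s1)Nc1ccc(Cl)cc1`: > 20000 nM

In a functional assay on HeLa cells (Homo sapiens) for inhibition, read by CCK-8 assay, with a stated time of 48 h (a lower number here means a stronger inhibitor, a higher number a weaker inhibitor), all three compounds report only limits: the limit of > 20000 nM in this assay, at which 2 of the 3 values shown sit, and (the limit of > 50000 nM in this assay, at which 1 of the 3 values shown sits). Compound 2 has no number, only the limit > 20000 nM. Compound 4 `Cc1cc(C)cc(NC(=O)NCCNS(=O)(=O)c2ccc(-c3ccccc3Oc3ccc(N)cc3)s2)c1` has 3,5-dimethylphenyl in place of 4-chlorophenyl on an amide-type nitrogen. For the measured compounds named here, the sole measured step, a step that the two limits leave unreadable from compound 2 to compound 3, has no readable size and changes a different group, so it offers no guide. Going by the values given here, no step of definite size or direction is therefore expected in this assay, and another limit is the likeliest report. The estimated step, a loose one, is a step that the limit leaves unreadable from compound 2 to compound 4. For compound 4 the expected value is 25000 nM, with an estimated range of 9000 nM to 60000 nM.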

Compound 4, half-maximal inhibitory concentration: > 20000 nM
Compound 4: a limit, no number (the forecaster's own chance of this, stated with the estimate: 70%); the middle value lies beyond the limit too.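

In this assay compound 4 gives > 20000 nM, a limit and not a number. Compound 2 gives > 20000 nM, also a limit. For the compounds shown here, no step between compound 2 and compound 4 can be read. As far as these compounds go, whether 3,5-dimethylphenyl and 4-chlorophenyl on the amide-type nitrogen differ at all remains open.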